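Shifting a Chlorophenyl Group: Compound 3 to Compound 4

The source may report more compounds than this note shows. Statements on the series, on what has been measured and on what is new or still open speak of the compounds shown alone.

Three compounds share one core, seen in compound 1 as `CC1=C(C(=O)Nc2ccc([N+](=O)[O-])cc2)C(c2ccc(Br)cc2)N=C(SCc2ccc(Cl)cc2)N1`, in compound 2 as `CC1=C(C(=O)Nc2ccc([N+](=O)[O-])cc2)C(c2cccc([N+](=O)[O-])c2)N=C(SCc2ccccc2Cl)N1` and in compound 3 as `CC1=C(C(=O)Nc2ccc([N+](=O)[O-])cc2)C(c2cccc([N+](=O)[O-])c2)N=C(SCc2cccc(Cl)c2)N1`. In a functional assay on the whole organism (artery, strain albino) with Rattus norvegicus as the target, with a stated time of 15 min, at a dose of 10 mg/kg by the oral route (a higher number here means more inhibition at the dose given (going by the name of the read-out), a lower number less inhibition), compound 1 gives 3.1%, compound 2 gives 2.1% and compound 3 gives 2.6%. Compound 3 stands in the middle of these three numbers, with compound 1 nearest and compound 2 furthest, all differences within the scatter. Going by the values given here, the only single-change step, a number 0.5 percentage points higher from compound 2 to compound 3 (within the scatter), also lies within the scatter. Compound 4, `CC1=C(C(=O)Nc2ccc([N+](=O)[O-])cc2)C(c2cccc([N+](=O)[O-])c2)N=C(SCc2ccc(Cl)cc2)N1`, differs from compound 3 by 4-chlorophenyl in place of 3-chlorophenyl on a saturated chain carbon bound to a sulfur. Because a number 0.5 percentage points higher from compound 2 to compound 3 (within the scatter) stayed within the scatter, no step beyond it is expected here. Compound 4 is therefore estimated at 2.6%, from -4% to 9%. The expected step is no change at the digits printed from compound 3 to compound 4 (within the scatter).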

Compound 4, a percentage reported as inhibition, in the whole organism at one dose (the size of the read-out at that dose, not a potency): 2.1%
Compound 4: middle estimate off by 0.5 percentage points, on the high side, and the stated range covers the measured number.
By their numbers in this assay, from the lowest: compounds 2, 4, 3 and 1 (each within the scatter of the next).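

With 4-chlorophenyl on the saturated chain carbon bound to a sulfur, this assay shows a number 0.5 percentage points lower from compound 3 to compound 4 (within the scatter) and no change at the digits printed from compound 2 to compound 4 (within the scatter) so that the 2-chlorophenyl, 3-chlorophenyl and 4-chlorophenyl forms cannot be told apart at this position. Going by these compounds alone, the first comparison at a second place, 3-nitrophenyl in place of 4-bromophenyl, gives a number 1 percentage points lower from compound 1 to compound 4 (within the scatter) on the saturated ring carbon, so neither change separates these compounds. Nothing available bears on why these readings sit so close together. As far as these compounds go, whether an amine or a carboxylic acid in place of the chlorophenyl group on that saturated chain carbon would give a reading beyond the scatter stays open.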